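The compounds below may be only part of what the source reports. "The series", "measured", "known", "first", "only" and "open" are said of these compounds alone.

Compound 1 `O=C(OC1=CC(=O)c2ccccc2C1=O)c1ccccc1` gives 36900 nM
Compound 2 `COc1ccc2c(c1)C(=O)C=CC2=O` gives 33900 nM

In a functional assay on KB cells (Homo sapiens) for cytotoxicity (a higher number here means a weaker inhibitor, a lower number a stronger inhibitor), compound 2 gives 33900 nM and compound 1 gives 36900 nM and these two values lie within the scatter of each other. Among the compounds with values here, compound 2 therefore cannot be separated from the only other measured compound. Compound 3 `CS(=O)(=O)Oc1ccc2c(c1)C(=O)C=CC2=O` differs from compound 2 in one place, with methylsulfonyl in place of methyl on an oxygen on an aromatic ring. The same difference reads as methoxy to (methylsulfonyl)oxy. Within the data shown here, no measured pair shows what a change of this kind does, so the expectation is a loose one. In this assay a modest move toward a lower number is expected, the estimated step being a 1.7-fold lower number from compound 2 to compound 3 (0.23 log units; within the scatter) and a result within the scatter remains quite possible. Compound 3 is estimated at 20000 nM (expected range 6000 nM to 60000 nM).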

Compound 3, half-maximal inhibitory concentration: 11600 nM
Estimate against measurement, compound 3: 1.7-fold (0.24 log units) above; the measured number falls inside the stated range.
By their numbers in this assay, from the lowest: compound 3; then compounds 2 and 1 (each within the scatter of the next).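

In this assay, replacing methoxy with (methylsulfonyl)oxy gives a clear separation (a 2.9-fold lower number from compound 2 to compound 3 (0.47 log units; beyond the scatter)), which lies beyond the scatter, whereas compound 1 and compound 2 could not be told apart. This shows that the read-out responds to what is carried on the oxygen on the aromatic ring, although the step is only modest and rests on a single pair. Nothing available explains why the number falls with this change.

The compounds shown leave open whether a free hydroxyl, an acetyl group or a longer chain such as butylsulfonyl on that same oxygen would lower the number further or raise it again. They also leave open whether methylsulfonyl in place of methyl would give a similar step on another core.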